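This account rests on a few compounds, and the source may have more. Where it says the series, first, only, none or still open, it means among the compounds named here.

Measured compounds:
compound 1 `CNS(=O)(=O)NC[C@@H]1CCCc2cc(S(=O)(=O)c3cccc(F)c3)ccc21` — 1 nM
compound 2 `CC(=O)N(C)C[C@@H]1CCCc2cc(S(=O)(=O)c3cccc(F)c3)ccc21` — 1.59 nM

In an assay on isolated protein for displacement of a labelled ligand from 5-hydroxytryptamine receptor 6 (Homo sapiens) (a higher number here means a weaker inhibitor, a lower number a stronger inhibitor), compound 1 gives 1 nM, the lowest of the two numbers shown; compound 2 gives 1.59 nM. Within the data shown here, the one measured step, a 1.6-fold higher number from compound 1 to compound 2 (0.20 log units; within the scatter), exchanges the (methylsulfamoyl)amino group for an acetyl(methyl)amino group and lies within the scatter, so the shared core with the arylsulfonyl group carries the potency largely on its own.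

Compound 3 `O=C(CO)NC[C@@H]1CCCc2cc(S(=O)(=O)c3cccc(F)c3)ccc21` is not yet measured. It differs from compound 1 as follows: (hydroxymethyl)carbonyl in place of methylsulfamoyl on an amine nitrogen. The substituent on the amine nitrogen is again replaced by a small, neutral group with one hydrogen-bond donor and two acceptors, as in the step from compound 1 to compound 2. That step bears directly on this one and was within the scatter, so no step beyond the scatter is expected here; compound 3 is expected at 1.5 nM (range 0.6 nM to 4 nM), a step of a 1.5-fold higher number from compound 1 to compound 3 (0.18 log units; within the scatter).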

Compound 3, inhibition constant: 0.1 nM
The estimate for compound 3 lay 15-fold (1.18 log units) above the measured number; measured number below the stated range.
By their numbers in this assay, from the lowest: compound 3; then compounds 1 and 2 (each within the scatter of the next).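

In this assay, (hydroxymethyl)carbonyl in place of methylsulfamoyl on the amine nitrogen gives a 10-fold lower number from compound 1 to compound 3 (1.00 log units; beyond the scatter), so this position does respond to a change of substituent, which the earlier step, within the scatter, did not show. ((Hydroxymethyl)carbonyl)amino in place of acetyl(methyl)amino gives a 16-fold lower number from compound 2 to compound 3 (1.20 log units; beyond the scatter), so the two earlier compounds do not mark the floor of the series at this position. The leaving methylsulfamoyl and the entering (hydroxymethyl)carbonyl have the same counts of hydrogen-bond donors and acceptors, so those counts do not track the step, and no measurement here accounts for it.

Open, from the compounds shown here alone, is whether the hydroxyl of compound 3 is needed, which a methoxyacetyl or plain acetyl group on the same amine nitrogen would test. Also open, going by these compounds, is whether a longer chain, such as 3-hydroxypropanoyl, keeps the number.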